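Swapping bromine for fluorine on a weak antiproliferative pair

The compounds below may be only part of what the source reports. "The series", "measured", "known", "first", "only" and "open" are said of these compounds alone.

Measured so far:
compound 1, `COc1cccc(Nc2nccc(-c3ccc(Br)cc3)n2)c1`: 82700 nM
compound 2, `Cc1ccc(-c2ccnc(Nc3ccc(Cl)cc3Cl)n2)cc1`: 164000 nM

Of the compounds shown here, two have been tested in a functional assay on A549 cells (Homo sapiens) for antiproliferative activity, read by MTT assay; a lower number here means a stronger inhibitor, a higher number a weaker inhibitor. Compound 1 gives 82700 nM, and compound 2 gives 164000 nM. These two numbers lie within the usual scatter of each other, so compound 1 is not separated from compound 2 on this assay; both are weak inhibitors.

Compound 3, `COc1cccc(Nc2nccc(-c3ccc(F)cc3)n2)c1`, has not yet been measured. It differs from compound 1 in one place: fluoro in place of bromo on an aromatic carbon. Within the data shown here, no step between two measured compounds of this kind is available, so nothing here shows how this change moves the number. Compound 1 itself gives 82700 nM, and the expected step of a 1.3-fold higher number from compound 1 to compound 3 (0.12 log units; within the scatter) is none beyond the scatter. Compound 3 is therefore expected to give about 110000 nM, with a range from 40000 nM to 300000 nM.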

Compound 3, half-maximal inhibitory concentration: 35900 nM
Compound 3: the middle estimate sits 3.1-fold (0.49 log units) above what was measured; the whole stated range lies above it.
By their numbers in this assay, from the lowest: compound 3; then compounds 1 and 2 (each within the scatter of the next).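

Fluoro in place of bromo on the 4-bromophenyl ring gives a 2.3-fold lower number from compound 1 to compound 3 (0.36 log units; beyond the scatter) in this assay. This shows that the number responds to a change at this one position, which the earlier pair could not show, as compound 1 and compound 2 differ in more than one place. The step is modest, and compound 3, at 35900 nM, is still a weak inhibitor; nothing available explains why this swap lowers the number.

This single pair cannot show whether the result reflects a wider trend or holds only for the core of compound 1. Going by these compounds, how a nitrile, an amine or a carboxylic acid in the same place would change the number also remains open.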